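The source may report more compounds than this note shows. Statements on the series, on what has been measured and on what is new or still open speak of the compounds shown alone.

Measured in a functional assay on CWR22R cells (Homo sapiens) for antiproliferative activity, read by CCK-8 assay, with a stated time of 6 days; a higher number here means a weaker inhibitor, a lower number a stronger inhibitor:
- Compound 1 `CCN(c1ccc(C#N)c(Cl)c1)c1cc(-c2ccnn2C)ccc1C`: 4330 nM
- Compound 2 `CCN(c1ccc(C#N)c(Cl)c1)c1cc(-c2ccc(F)nc2)ccc1C`: 16500 nM
- Compound 3 `CCN(c1ccc(C#N)c(Cl)c1)c1cc(-n2ccnc2)ccc1C`: > 30000 nM

Going by these compounds, the entry for compound 3 is a limit of the assay, not a number, so its true position on the scale is unknown.

Compound 4 `CCN(c1ccc(C#N)c(Cl)c1)c1cc(-c2cccnc2)ccc1C` carries pyridin-3-yl in place of 1H-imidazol-1-yl on an aromatic carbon. Two measured steps end in that same 1H-imidazol-1-yl group. The first is an at least 6.9-fold higher number from compound 1 to compound 3 (0.84 log units; beyond the scatter), and the second is an at least 1.8-fold higher number from compound 2 to compound 3 (0.25 log units; that floor lies within the scatter). Both point the same way, although only the first clearly exceeds the scatter. The closest comparison for the incoming group is compound 2 at 16500 nM, which carries 6-fluoropyridin-3-yl. Leaving 1H-imidazol-1-yl should therefore lower the number, probably to a level near compound 2 rather than compound 1. The expected change is an at least 2.5-fold lower number from compound 3 to compound 4 (0.39 log units; beyond the scatter). In this assay the estimate for compound 4 is 12000 nM, with an expected range of 5000 nM to 30000 nM.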

Compound 4, half-maximal inhibitory concentration: 2000 nM
The estimate for compound 4 lay 6.0-fold (0.78 log units) above the measured number; the measured number lies below the stated range.
By their numbers in this assay, from the lowest: compound 4; then compound 1; then compound 2. At a limit, above all of these: compound 3.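

In this assay, compound 4, with a plain pyridin-3-yl on this aromatic carbon, gives the lowest number of the series, with a 2.2-fold lower number from compound 1 to compound 4 (0.34 log units; beyond the scatter) and an 8.3-fold lower number from compound 2 to compound 4 (0.92 log units; beyond the scatter). Compound 2 had placed a six-membered aromatic ring behind 1-methyl-1H-pyrazol-5-yl, but compound 4 shows that this order held only with the fluoro present, and that hydrogen in its place reverses it. The step away from 1H-imidazol-1-yl is an at least 15-fold lower number from compound 3 to compound 4 (1.17 log units; beyond the scatter), and it has only a floor, as compound 3 is held at a limit of the assay: the limit of > 30000 nM in this assay, at which 1 of the 4 values shown sits.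

Going by these compounds, whether the ring nitrogen of pyridin-3-yl matters at all remains open, and a plain phenyl ring would test it. Also open, on these data alone, is how a methoxy group or an amine would fare where the fluoro sits in compound 2.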